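The source may report more compounds than this note shows. Statements on the series, on what has been measured and on what is new or still open speak of the compounds shown alone.

In a functional assay on NCI-H460 cells (Homo sapiens) for cytotoxicity, read by MTT assay, with a stated time of 72 h (on this read-out higher numbers stand for weaker inhibition and lower numbers for stronger inhibition), compound 1 (`CN(C)Cc1ccc2nc(NC(=O)N/N=C/c3cn(Cc4ccccc4Cl)c4ccccc34)sc2c1`) gives 1600 nM and compound 2 (`Cc1ccc(Cn2cc(/C=N/NC(=O)Nc3nc4ccc(CN(C)C)cc4s3)c3ccccc32)cc1`) gives 200 nM, the lower of the two numbers. The change to compound 3 (`CN(C)Cc1ccc2nc(NC(=O)N/N=C/c3cn(Cc4ccc(Cl)c(Cl)c4)c4ccccc34)sc2c1`) is 3,4-dichlorophenyl in place of 4-methylphenyl on a saturated chain carbon bound to an aromatic nitrogen. Among the compounds with values here, only one measured step bears on this place, an 8.0-fold lower number from compound 1 to compound 2 (0.90 log units; beyond the scatter), and there the chlorine-bearing compound 1 holds the higher number. One step is thin evidence, so only a modest rise is expected in this assay, as the expected 2.0-fold higher number from compound 2 to compound 3 (0.30 log units; within the scatter). The estimate for compound 3 is 400 nM, with an expected range of 100 nM to 1600 nM.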

Compound 3, half-maximal inhibitory concentration: 1360 nM
Compound 3: middle estimate off by 3.4-fold (0.53 log units), on the low side; low and high end bracket the measured number.
By their numbers in this assay, from the lowest: compound 2; then compounds 3 and 1 (each within the scatter of the next).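

In this assay, the low number of compound 2 does not extend to a second chlorine-bearing ring at this position: the change to 3,4-dichlorophenyl gives (a 6.8-fold higher number from compound 2 to compound 3 (0.83 log units; beyond the scatter)). The two chlorine-bearing groups do not separate from each other (a 1.2-fold lower number from compound 1 to compound 3 (0.07 log units; within the scatter)), so among these compounds only the 4-methylphenyl group stands apart. Nothing available explains these differences. The compounds shown leave open whether a plain phenyl, 4-chlorophenyl or 4-methoxyphenyl group would give a number like that of compound 2 or like those of the chlorine-bearing pair.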